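This account rests on a few compounds, and the source may have more. Where it says the series, first, only, none or still open, it means among the compounds named here.

Compound 1 `COc1ccccc1-n1cc(CN2C(=O)C[C@@H]3CC[C@@]2(C)C3(C)C)nn1`: 140 nM
Compound 2 `Cc1ccc(-n2cc(CN3C(=O)C[C@@H]4CC[C@@]3(C)C4(C)C)nn2)cc1`: 40 nM

In a functional assay on OVCAR-3 cells (Homo sapiens) for inhibition, read by MTT assay, with a stated time of 24 h (a higher number here means a weaker inhibitor, a lower number a stronger inhibitor), compound 2 holds the lower of the two numbers, 40 nM, which makes it the stronger inhibitor so far. Compound 3 `Cc1cccc(-n2cc(CN3C(=O)C[C@@H]4CC[C@@]3(C)C4(C)C)nn2)c1` has the same atoms joined differently: 3-methylphenyl in place of 4-methylphenyl on an aromatic nitrogen. Only 3-methylphenyl replaces 4-methylphenyl, and the rest of the molecule stays the same.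

Among the measured compounds shown here, only one measured step bears on this change: a 3.5-fold lower number from compound 1 to compound 2 (0.54 log units; beyond the scatter). That modest step replaced 2-methoxyphenyl with 4-methylphenyl, so it changed the group as well as its place on the phenyl ring. It therefore cannot show what moving the methyl alone does, and it serves only as a rough guide to size. A small rise in the number is expected, with low confidence in its direction. The expected step is a 1.5-fold higher number from compound 2 to compound 3 (0.18 log units; within the scatter), probably within the scatter. For compound 3 the estimate is 60 nM, with an expected range of 20 nM to 180 nM.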

Compound 3, half-maximal inhibitory concentration: 160 nM
For compound 3 the middle estimate is 2.7-fold (0.43 log units) below the measured one; low and high end bracket the measured number.
By their numbers in this assay, from the lowest: compound 2; then compounds 1 and 3 (each within the scatter of the next).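

Moving a single methyl matters in this assay: with the same atoms in the group, 3-methylphenyl in place of 4-methylphenyl gives a 4.0-fold higher number from compound 2 to compound 3 (0.60 log units; beyond the scatter), whereas the earlier pair changed the group and its place together and could not isolate this. The change from 2-methoxyphenyl to 3-methylphenyl gives a 1.1-fold higher number from compound 1 to compound 3 (0.06 log units; within the scatter), so these two compounds cannot be told apart here, and only the 4-methylphenyl of compound 2 stands clear of the other two. Nothing available explains why the place of the methyl matters.

Going by these compounds, it remains open whether the methyl itself matters or whether other groups would serve equally well where it sits in 4-methylphenyl. A chlorine atom or a methoxy group in place of that methyl would address this, as would a plain phenyl without any added group.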